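The source may hold more compounds than are shown below. What is called first, only, known or untested is meant among the compounds shown, and "the series" means these compounds.

Measured so far in an ADME assay on a cell-free system (plasma, Homo sapiens) for metabolic stability, with Plasma (Rattus norvegicus) as the target, read by HPLC, at pH 7.4; on this read-out lower numbers stand for a shorter-lived compound and higher numbers for a longer-lived compound:
Compound 1 `CCCCC(=O)O[C@@H]1CO[C@H]2[C@@H]1OC[C@@H]2OC(=O)c1ccccc1OC(C)=O` gives 0.0198 h.
Compound 2 `CC(=O)Oc1ccccc1C(=O)O[C@H]1CO[C@H]2[C@@H]1OC[C@H]2OC(=O)c1ccccc1C` gives 0.035 h.
Compound 3 `CC(=O)Oc1ccccc1C(=O)O[C@H]1CO[C@H]2[C@@H]1OC[C@H]2OC(=O)c1ccc(-c2ccccc2)cc1` reaches only a limit of this assay, > 0.333 h.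

Compound 1 stands lowest of the two plain numbers; its nearest neighbour is compound 2, with a 1.8-fold higher number from compound 1 to compound 2 (0.25 log units; within the scatter). Compound 4 `CC(=O)Oc1ccccc1C(=O)O[C@H]1CO[C@H]2[C@@H]1OC[C@H]2OC(=O)c1ccc(CO[N+](=O)[O-])cc1` differs from compound 1 in one place: 4-((nitrooxy)methyl)phenyl in place of butyl on a carbonyl carbon. Among the compounds with values here, two measured steps bear on this change, both putting an aromatic ring in place of butyl on the same carbonyl carbon: a 1.8-fold higher number from compound 1 to compound 2 (0.25 log units; within the scatter) and an at least 16-fold higher number from compound 1 to compound 3 (1.22 log units; beyond the scatter), where compound 3 sits at the limit of > 0.333 h in this assay, at which 1 of the 3 values shown sits. An aromatic ring in that place has therefore given a longer-lived compound each time, by a size ranging from within the scatter to large. Compound 4 is expected at 0.06 h, between 0.025 h and 0.2 h. That estimate means a 3.0-fold higher number from compound 1 to compound 4 (0.48 log units; beyond the scatter), a modest step toward a longer half-life.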

Compound 4, half-life: 0.1 h
Compound 4: the middle estimate sits 1.7-fold (0.22 log units) below what was measured; measured number inside the range.
By their numbers in this assay, from the lowest: compounds 1 and 2 (each within the scatter of the next); then compound 4. At a limit, above all of these: compound 3.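

In this assay a third aromatic ring in place of butyl on this carbonyl carbon gives a 5.1-fold higher number from compound 1 to compound 4 (0.70 log units; beyond the scatter) and so again a longer-lived compound. Which group the ring carries also counts: a 2.9-fold higher number from compound 2 to compound 4 (0.46 log units; beyond the scatter) separates the 2-methylphenyl and 4-((nitrooxy)methyl)phenyl compounds, and an at least 3.3-fold lower number from compound 3 to compound 4 (0.52 log units; beyond the scatter) comes with (nitrooxy)methyl in place of phenyl on an aromatic carbon. That last step is open-ended, as compound 3 stands at a limit: the limit of > 0.333 h in this assay, at which 1 of the 4 values shown sits.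

The compounds shown leave open where an amine or a longer chain on that aromatic ring would fall.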